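This account rests on a few compounds, and the source may have more. Where it says the series, first, only, none or still open, it means among the compounds named here.

Measured so far:
compound 1 `C[C@@H](Nc1c(C(=O)NCc2ccc(F)cc2)nc(Br)c2cccnc12)c1ccccc1` — in a functional assay on HCT-116 cells (Homo sapiens) for cytotoxicity, read by MTT assay, with a stated time of 72 h; on this read-out lower numbers stand for stronger inhibition and higher numbers for weaker inhibition: > 20000 nM
compound 2 `N[C@H]1CC[C@H](Nc2c(C(=O)NCc3ccco3)nc(Br)c3cccnc23)CC1` — this assay: > 10000 nM
compound 3 `N[C@H]1CC[C@H](Nc2c(C(=O)NCc3cccc(C(F)(F)F)c3)nc(Br)c3cccnc23)CC1` — this assay: "not determined" (no result reported)

Compound 1 stands only at a limit of this assay and not at a number: its value is the limit of > 20000 nM in this assay, at which 1 of the 3 values shown sits. Compound 2 likewise sits at a limit, (the limit of > 10000 nM in this assay, at which 1 of the 3 values shown sits), and for compound 3 no result is given, so none of the three gives a number to rank against. For the measured compounds named here, there is thus no measured step within this set, and compound 1 can only be said to lie at the weak end of what this assay can report.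

Compound 4 `O=C(NCc1ccc(F)cc1)c1nc(Br)c2cccnc2c1NCCO` differs from compound 1 in one place: 2-hydroxyethyl in place of 1-phenylethyl on a nitrogen on an aromatic ring. Going by the values given here, no measured pair shows what such a change does here. Since compound 1 already gives > 20000 nM, a limit, there is little room for a shift to be seen toward weaker inhibition, and nothing among the shown compounds points to the change bringing stronger inhibition. The expected step is therefore small, a step that the limit leaves unreadable from compound 1 to compound 4, within the scatter.

Compound 4 is expected to give about 30000 nM, with a range from 10000 nM to 100000 nM, most likely again reported only as a limit.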

Compound 4, half-maximal inhibitory concentration: > 20000 nM
Compound 4 ended at the assay's limit; the forecaster's own chance of this, stated with the estimate: 85%; the middle value lies beyond the limit too.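

Compound 1 and compound 4 both sit at a limit of this assay and not at a number, so no step can be read for 2-hydroxyethyl in place of 1-phenylethyl. The compounds shown leave open whether any group on this nitrogen would give a measured number in this assay.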